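Half-life of compound 2 and its cyclopropyl analogue

A few compounds are considered here, and "the series" means these few. Any claim that something is new, unique, unknown or untested is made for them only; others in the source may bear on it.

- compound 1 `CCn1c(-c2cnc(C)nc2)nc2c(O[C@H]3CCN(C(=O)C4CCOC4)C3)ncnc21` in an ADME assay (Rattus norvegicus, strain Wistar Han) for metabolic stability (a lower number here means that the compound disappears faster, a higher number that the compound lasts longer), gives 1.4 h
- compound 2 `CCn1c(-c2cnc(C)nc2)nc2c(N[C@H]3CCN(C(=O)C4CCOC4)C3)ncnc21` in this assay gives 0.6 h

Compound 2 has the lower number of the two at 0.6 h while compound 1 reaches 1.4 h and this gap lies beyond the scatter of repeated measurements. Among the compounds with values here, compound 3 `CCn1c(-c2cnc(C)nc2)nc2c(N[C@H]3CCN(C(=O)C4CC4)C3)ncnc21` departs from compound 2 at one place, with cyclopropyl in place of oxolan-3-yl on a carbonyl carbon and no measured pair shows this exchange. With nothing to set a direction, no step beyond the scatter is expected in this assay for this change. The expected step of a 1.2-fold higher number from compound 2 to compound 3 (0.07 log units; within the scatter) is therefore small. Compound 3 is expected at an estimated 0.7 h in this assay with 0.35 h to 1.4 h as the likely range.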

Compound 3, half-life: 2.7 h
Estimate against measurement, compound 3: 3.9-fold (0.59 log units) below; the whole stated range lies below it.
By their numbers in this assay, from the lowest: compound 2; then compounds 1 and 3 (each within the scatter of the next).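

In this assay the group on this carbonyl carbon is not a neutral place in the series: cyclopropyl in place of oxolan-3-yl gives a 4.5-fold higher number from compound 2 to compound 3 (0.65 log units; beyond the scatter), beyond the scatter and the first direction seen for this exchange. The change removes a ring oxygen and shortens the ring, but this is a difference in counted atoms, and it rests on a single pair. Nothing at hand bears on why the half-life moves.

Going by these compounds, whether the same exchange carries over to the core of compound 1 remains open. So does the behaviour of other groups on this carbonyl carbon, such as a methyl, a cyclobutyl or an oxetanyl, and therefore whether the effect belongs to cyclopropyl itself or to the loss of oxolan-3-yl.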